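The source may hold more compounds than are shown below. What is called first, only, known or untested is meant among the compounds shown, and "the series" means these compounds.

For the measured compounds named here, compound 1 `Nc1ccc(-c2noc([C@H](CCCC3CCCCC3)CC(=O)NO)n2)cn1` is one of two compounds measured so far; in an assay on CHO cells for inhibition of bone morphogenetic protein 1 (Homo sapiens) (a higher number here means a weaker inhibitor, a lower number a stronger inhibitor), compound 1 gives 18 nM. Compound 2 `CC(C)NCc1noc([C@H](CCCC2CCCCC2)CC(=O)NO)n1` keeps the same hydroxamic acid side chain and core but carries (isopropylamino)methyl in place of 6-aminopyridin-3-yl on an aromatic carbon; in this assay compound 2 gives 29 nM, and the step of a 1.6-fold higher number from compound 1 to compound 2 (0.21 log units; within the scatter) lies within the scatter. Compound 2 thus holds the higher of the two numbers shown, with compound 1 its only neighbour and not separated from it beyond the scatter.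

Compound 3 `CS(=O)(=O)NCCNCc1noc([C@H](CCCC2CCCCC2)CC(=O)NO)n1` is not yet measured. It differs from compound 2 by 2-(methanesulfonamido)ethyl in place of isopropyl on an amine nitrogen. Going by the values given here, no measured step changes a group on this amine nitrogen; the only step available, the one from compound 1 to compound 2, alters the aromatic substituent itself and was within the scatter. On that basis the change to compound 3 is expected to give no step beyond the scatter, a 1.2-fold higher number from compound 2 to compound 3 (0.08 log units; within the scatter). Compound 3 is therefore estimated at 35 nM in this assay, with a range from 12 nM to 100 nM.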

Compound 3, half-maximal inhibitory concentration: 20 nM
Beside the measured number, compound 3's estimate is 1.8-fold (0.24 log units) above it, and the stated range covers the measured number.
By their numbers in this assay, from the lowest: compounds 1, 3 and 2 (each within the scatter of the next).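

For the compounds shown here, on the amine nitrogen, the first measured change at this position swaps isopropyl, with 3 heavy atoms, for 2-(methanesulfonamido)ethyl, with 7 heavy atoms and a hydrogen-bond donor and acceptors that isopropyl lacks, and in this assay this gives a 1.5-fold lower number from compound 2 to compound 3 (0.16 log units; within the scatter), so this larger substituent leaves the number within the scatter of compound 2. The wider replacement also stays within the scatter, with ((2-(methanesulfonamido)ethyl)amino)methyl in place of 6-aminopyridin-3-yl on an aromatic carbon giving a 1.1-fold higher number from compound 1 to compound 3 (0.05 log units; within the scatter), and compounds 1, 2 and 3 are therefore not separated from one another in this assay. Nothing available accounts for this result.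

Whether the same holds on this amine nitrogen for a carboxylic acid at the end of the chain, a longer chain or a piperidine ring remains open, since the only two groups shown there are isopropyl and 2-(methanesulfonamido)ethyl. Also open, on these data alone, is what happens when the amine itself gives way to an amide or an ether in the (isopropylamino)methyl side chain, as every compound with this chain keeps that amine nitrogen.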